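Removing the methoxy group from compound 1

The source may hold more compounds than are shown below. What is called first, only, known or untested is meant among the compounds shown, and "the series" means these compounds.

Going by the values given here, compound 1 `COc1ccc(CNc2nc(SC)nc3ncccc23)cc1` is the only member of this small set with a read-out in a functional assay on HT-29 cells (Homo sapiens) for cytotoxicity, read by MTT assay, with a stated time of 72 h; on this read-out lower numbers stand for higher toxicity in this test and higher numbers for lower toxicity in this test. In this assay compound 1 gives > 100000 nM, which is a limit of the assay and not a number. Compound 2 `C[Se]c1nc([Se]C)c2cccnc2n1` gives "not determined" (no result reported) in this assay. Compound 3 `[SeH]c1nc([SeH])c2cccnc2n1` likewise gives "not determined" (no result reported) in this assay. Compound 4 `CSc1nc(NCc2ccccc2)c2cccnc2n1` is not yet measured and differs from compound 1 by hydrogen in place of methoxy on an aromatic carbon. Among the compounds with values here, no step between measured compounds is available, so the size of this change cannot be read from the data; no shift beyond the usual scatter is expected, because compound 1 already sits at the limit of > 100000 nM in this assay, at which 1 of the 3 values shown sits. Compound 4 is therefore expected to give 100000 nM, within 30000 nM to 300000 nM, most likely again reported only as a limit. The step of a number no higher from compound 1 to compound 4 (the limit leaves the size open) is expected to lie within the scatter.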

Compound 4, concentration lethal to 50% of the cells: > 100000 nM
Compound 4 was reported as a limit; the forecaster's own chance of this, stated with the estimate: 80%; the middle value lies on the limit itself.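

Compound 1 and compound 4 both stand at a limit of the assay and not at a number, so no step between them can be read: the limit of > 100000 nM in this assay, at which 2 of the 4 values shown sit.

The compounds shown leave open whether hydrogen in place of methoxy changes the read-out at all.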